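The source may hold more compounds than are shown below. What is called first, only, known or untested is meant among the compounds shown, and "the series" means these compounds.

Compound 1 `CCc1cccc2c(OC)c(-c3occ(C)c3C(=O)NC)ccc12` in a functional assay on A549 cells (Homo sapiens) for cytotoxicity, read by MTT assay, with a stated time of 72 h (a higher number here means that more compound is needed for the effect, a lower number that less compound is needed), gives > 10 ug/mL, which is a limit of the assay and not a number. Compound 2 `CCc1cccc2c(OC)c(-c3occ(C)c3COC)ccc12` in this assay gives > 10 ug/mL, again a limit. Compound 3 `CCc1cccc2c(OC)c(-c3occ(C)c3CBr)ccc12` in this assay gives > 10 ug/mL, also a limit.

Compound 3 therefore stands where the other two stand: all three values sit at the limit of > 10 ug/mL in this assay, at which 3 of the 3 values shown sit, and no one of the three can be placed above or below another. The steps among them are a step that the two limits leave unreadable from compound 1 to compound 2, a step that the two limits leave unreadable from compound 1 to compound 3 and a step that the two limits leave unreadable from compound 2 to compound 3; none of them has a readable size, because each joins two limits (the limit of > 10 ug/mL in this assay, at which 3 of the 3 values shown sit).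

Compound 4 `CCc1cccc2c(OC)c(-c3occ(C)c3COC(=O)CCN(CC)CC)ccc12` differs from compound 3 in one place: ((2-(diethylamino)ethyl)carbonyl)oxy in place of bromo on a saturated chain carbon bound to an aromatic carbon. Among the measured compounds shown here, the only measured steps that bear on this change are the three just named, and all of them are unreadable. No size or direction of step in this assay can be read from them, so there is no ground to expect a step beyond the usual scatter, while a step in either direction remains possible.

Compound 4 is thus estimated to give 15 ug/mL, within a range from 4 ug/mL to 50 ug/mL. The step this estimate means is expected to be a step that the limit leaves unreadable from compound 3 to compound 4.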

Compound 4, concentration for half-maximal effect: > 10 ug/mL
Compound 4 ended at the assay's limit; the forecaster's own chance of this, stated with the estimate: 60%; the middle value is on the limit's open side.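

The steps to compound 4 from compound 3 and from compound 2 cannot be read, because each joins two limits and neither has a size: the limit of > 10 ug/mL in this assay, at which 4 of the 4 values shown sit.

Whether any change among compound 1, compound 2, compound 3 and compound 4 alters the result in this assay is left open by the compounds shown.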